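Compound 4: cyclopropyl on the carbonyl in place of ethyl

The source may hold more compounds than are shown below. What is called first, only, known or untested is meant among the compounds shown, and "the series" means these compounds.

Values in an ADME assay on a cell-free system (plasma, Rattus norvegicus, strain Wistar Han) for protein binding:
- compound 1 `CCn1ncc(-c2nc3c(O[C@H]4CCN(C(=O)C5CCOCC5)C4)ncnc3n2C)c1C`: 27%
- compound 2 `CCn1ncc(-c2nc3c(O[C@H]4CCN(C(=O)C5CC5)C4)ncnc3n2C)c1C`: 67%
- compound 3 `CCC(=O)N1CC[C@H](Nc2ncnc3c2nc(-c2cnn(CC)c2C)n3C)C1`: 51%

Compound 3, at 51%, lies within the usual scatter of both compound 1 and compound 2 in this assay. The next compound, compound 4 `CCn1ncc(-c2nc3c(N[C@H]4CCN(C(=O)C5CC5)C4)ncnc3n2C)c1C`, differs from it in one place: cyclopropyl in place of ethyl on a carbonyl carbon. This puts cyclopropyl in place of ethyl on a carbonyl carbon, turning propanoyl into cyclopropylcarbonyl.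

Among the measured compounds shown here, only one measured step bears on this change: a 2.2-fold lower unbound fraction from compound 1 to compound 2 (0.34 log units; beyond the scatter). That modest step also brings in cyclopropyl on a carbonyl carbon, but oxan-4-yl leaves there rather than ethyl, and compound 1 and compound 2 differ from compound 3 elsewhere as well. It therefore offers a direction and only a loose guide to size. For the measured compounds named here, no measured step has ethyl leaving. A small move toward more binding is expected, smaller than the measured step and probably within the scatter. The expected change is a 1.2-fold lower unbound fraction from compound 3 to compound 4 (0.07 log units; within the scatter). For compound 4 the estimated value is 58%, with an expected range of 42% to 72%.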

Compound 4, plasma protein binding: 72%
For compound 4 the middle estimate is 1.5-fold (0.18 log units) (unbound fraction) above the measured one; low and high end bracket the measured number.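

Among the compounds shown here, compound 4 gives the first direct reading of ethyl leaving this carbonyl carbon, where it sits with an amide-type nitrogen in a ring, and in this assay the exchange for cyclopropyl comes to a small step (a 1.8-fold lower unbound fraction from compound 3 to compound 4 (0.24 log units; within the scatter)). Read alone, this step cannot be told apart from repeat measurement, so propanoyl and cyclopropylcarbonyl are not separated at this position. Cyclopropyl has now entered on this carbonyl carbon in two measured steps, and only the one in which oxan-4-yl leaves (a 2.2-fold lower unbound fraction from compound 1 to compound 2 (0.34 log units; beyond the scatter)) clears the scatter, while the data offer nothing that explains the result or the contrast between the two steps.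

The compounds shown leave open whether a longer chain than ethyl, or a group on this carbonyl carrying an amine or a carboxylic acid, would produce a step beyond the scatter in this assay. They also do not tell whether the exchange of ethyl for cyclopropyl would read the same with the oxygen link to the shared core found in compound 2, rather than the nitrogen link found in compound 4.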